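A few compounds are considered here, and "the series" means these few. Any claim that something is new, unique, unknown or untested is made for them only; others in the source may bear on it.

Values so far in an ADME assay on MRC5 cells (Homo sapiens) for antiproliferative activity, read by fluorescence and resazurin assay, with a stated time of 68 h; on this read-out higher numbers stand for an effect only at larger amounts of compound and lower numbers for an effect already at smaller amounts:
- compound 1 `O=C(NCCN1CCCC1)c1cc(NCCN2CCCCC2)nc2ccc(F)cc12` gives 19000 nM
- compound 2 `CN(C)c1ccc(-c2cc(C(=O)NCCN3CCCC3)c3cc(F)ccc3n2)cc1` gives 10000 nM
- compound 3 `O=C(NCCN1CCCC1)c1cc(-c2ccc(S(=O)(=O)N3CCOCC3)cc2)nc2ccc(F)cc12` gives 21000 nM

Going by the values given here, compound 3 stands level with compound 1 and above compound 2, the only one of the pair from which it is separated beyond the scatter. Compound 4 `O=C(NCCN1CCCC1)c1cc(-c2ccc(C(=O)N3CCOCC3)cc2)nc2ccc(F)cc12` differs from compound 3 by (morpholin-4-yl)carbonyl in place of (morpholin-4-yl)sulfonyl on an aromatic carbon, with (morpholin-4-yl)carbonyl in place of (morpholin-4-yl)sulfonyl on an aromatic carbon, para to a large group.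

The closest evidence is a 2.1-fold higher number from compound 2 to compound 3 (0.32 log units; beyond the scatter), a modest change at the same place. The other step, a 1.9-fold lower number from compound 1 to compound 2 (0.28 log units; within the scatter), is also small. Among the compounds with values here, no measured step compares carbonyl with sulfonyl directly, so no step beyond the scatter is expected in this assay. The expected step is a 1.2-fold lower number from compound 3 to compound 4 (0.09 log units; within the scatter). For compound 4 the estimated value is 17000 nM, with an expected range of 9000 nM to 32000 nM.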

Compound 4, half-maximal effective concentration: > 50000 nM
Compound 4: only a limit was reported (the forecaster's own chance of this, stated with the estimate: 10%); middle value at least 2.9-fold (0.46 log units) from the limit.
By their numbers in this assay, from the lowest: compounds 2, 1 and 3 (each within the scatter of the next, the first and the last beyond it). At a limit, above all of these: compound 4.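

In this assay compound 4 gives only a limit: the limit of > 50000 nM in this assay, at which 1 of the 4 values shown sits.

On an aromatic carbon para to a large group, (morpholin-4-yl)carbonyl in place of (morpholin-4-yl)sulfonyl is not a silent exchange, with an at least 2.3-fold higher number from compound 3 to compound 4 (0.37 log units; beyond the scatter). Against dimethylamino at the same place, the step widens to an at least 5.0-fold higher number from compound 2 to compound 4 (0.69 log units; beyond the scatter), so this position spans more than the earlier steps showed.

From the compounds shown here alone, the true size of both steps remains open. Also open, going by these compounds, is where a carboxylic acid or a primary amine on this aromatic carbon would fall.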